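A few compounds are considered here, and "the series" means these few. Any claim that something is new, unique, unknown or untested is made for them only; others in the source may bear on it.

Measured compounds:
Compound 1 `Cc1cccc(Oc2ccnc(N3CCC[C@H]3C(=O)NCc3cccnc3)n2)c1`: 0%; 0% (2 entries)
Compound 2 `Cc1cccc(Oc2ccnc(N3CCC[C@H]3C(=O)NCCCn3ccnc3)n2)c1`: 0%

In an assay on isolated protein for inhibition of calcium/calmodulin-dependent protein kinase type IV (Homo sapiens), read by HTRF, tested at 10 uM (on this read-out higher numbers stand for more inhibition at the one concentration tested (going by the name of the read-out) and lower numbers for less inhibition), compound 1 gives 0%; 0% (2 entries) in each of two entries. Compound 2 gives 0% in this assay; this is the only number shown for compound 2, and one further measurement of it yielded no single number. The two compounds therefore sit together at the bottom of the scale, with neither showing inhibition at the tested concentration, and their values lie within the scatter of each other.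

Compound 3 `COC(=O)C(CO)NC(=O)[C@@H]1CCCN1c1nccc(Oc2cccc(C)c2)n1` differs from compound 2 in one place: 2-hydroxy-1-(methoxycarbonyl)ethyl in place of 3-(1H-imidazol-1-yl)propyl on an amide-type nitrogen. No measured pair with this change is available, so the expectation rests on the compounds shown. The expected step from compound 2 to compound 3 in this assay is a number 2 percentage points higher from compound 2 to compound 3 (within the scatter), that is, none beyond the scatter. For compound 3 the estimate in this assay is 2%, with a range from -8% to 14%.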

Compound 3, a percentage reported as inhibition, at one concentration (the size of the read-out at that concentration, not a potency): 0%
The estimate for compound 3 lay 2 percentage points above the measured number; low and high end bracket the measured number.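

In this assay, putting 2-hydroxy-1-(methoxycarbonyl)ethyl in place of 3-(1H-imidazol-1-yl)propyl on the amide-type nitrogen gives no change at the digits printed from compound 2 to compound 3 (within the scatter). Among the compounds shown here, the earlier compounds carried only ring-bearing groups at this position, so this is the first sign that a group with no ring, holding a hydroxyl and a methyl ester, also leaves the read-out at the bottom of the scale. No measured evidence bears on why the read-out stays there.

The compounds shown leave open whether any group on this nitrogen, such as a carboxylic acid or a longer chain ending in an amine, can produce measurable inhibition. From the compounds shown here alone, with every value at the bottom of the scale, a loss of inhibition could not show, so the importance of this position remains unknown.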